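The source may hold more compounds than are shown below. What is called first, only, known or untested is meant among the compounds shown, and "the series" means these compounds.

Working notes on the series. In an ADME assay on HepG2 cells (Homo sapiens) for cytotoxicity, with a stated time of 72 h (a higher number here means that more compound is needed for the effect, a lower number that less compound is needed), compound 1 `Cc1cc(NC(=O)Nc2ccc(N(C)C)cc2)c2ccccc2n1` gives > 25000 nM, which is a limit of the assay and not a number. Compound 2 `Cc1cc(NC(=O)Nc2ccccc2C(N)=O)c2ccccc2n1` gives > 25000 nM, also a limit. Compound 1 therefore has no exact position on the scale, and the record so far stands at the limit of > 25000 nM in this assay, at which 2 of the 2 values shown sit.

The next compound to be tested is compound 3 `Cc1cc(NC(=O)Nc2ccc(SC(F)(F)F)cc2)c2ccccc2n1`, which keeps the core of compound 1 and carries (trifluoromethyl)sulfanyl in place of dimethylamino on an aromatic carbon, para to a large group: (trifluoromethyl)sulfanyl in place of dimethylamino on an aromatic carbon.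

Among the measured compounds shown here, no measured step between compounds that differ in one place is available, so the size of this change in this assay cannot be read from the series. A modest move toward less compound needed is expected, and a second reading at the limit would be no surprise. The estimated step is an at least 1.2-fold lower number from compound 1 to compound 3 (0.09 log units; that floor lies within the scatter). For compound 3, the expected value is 20000 nM, with an estimated range of 8000 nM to 30000 nM.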

Compound 3, half-maximal effective concentration: 20000 nM
The estimate for compound 3 equals the measured number at the digits printed; the measured number falls inside the stated range.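

In this assay, compound 3 is the only compound shown with an exact reading, so this position, an aromatic carbon para to a large group, now has a number on the scale and not only limits. Replacing dimethylamino with (trifluoromethyl)sulfanyl gives an at least 1.2-fold lower number from compound 1 to compound 3 (0.09 log units; that floor lies within the scatter); the step is known only as a floor, and this floor alone does not establish a real difference between the two compounds. The other readings in the series remain at the limit of the assay, which gives no exact value to set against compound 3: the limit of > 25000 nM in this assay, at which 2 of the 3 values shown sit.

From the compounds shown here alone, it remains open how far the true step from dimethylamino to (trifluoromethyl)sulfanyl extends beyond that floor, and whether any replacement at this position can move the reading beyond the usual scatter. Going by these compounds, it is equally open how a carboxylic acid, a primary amine or a longer alkyl chain on the same aromatic carbon would read in this assay, and whether such groups would stay at the limit or give exact values.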